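Cyano in place of methoxycarbonyl on a shared core

The source may hold more compounds than are shown below. What is called first, only, known or untested is meant among the compounds shown, and "the series" means these compounds.

Compound 2 `COC(=O)c1c(-c2ccccc2)c(-c2ccccc2)n(CCCCCCNC(=O)Oc2ccccc2)c1C` stands only at a limit in an assay on microsomes from brain (strain Sprague-Dawley) for inhibition of Fatty-acid amide hydrolase 1 (Rattus norvegicus), read by fluorescence and HPLC, with stated times of 10 min and 60 min; a higher number here means a weaker inhibitor, a lower number a stronger inhibitor: compound 2 gives > 10000 nM, which is a limit of the assay and not a number. Compound 1 `CC(=O)c1c(-c2ccccc2)c(-c2ccccc2)n(CCCCCCNC(=O)Oc2ccccc2)c1C` likewise gives only a limit, > 10000 nM. The step that the two limits leave unreadable from compound 1 to compound 2 therefore cannot be read, as the limit of > 10000 nM in this assay, at which 2 of the 2 values shown sit, shows. Compound 3 `Cc1c(C#N)c(-c2ccccc2)c(-c2ccccc2)n1CCCCCCNC(=O)Oc1ccccc1` differs from compound 2 by cyano in place of methoxycarbonyl on an aromatic carbon. Among the compounds with values here, no measured step bears readably on this change, so no shift beyond the scatter in this assay can be expected in either direction. Compound 3 is estimated at 10000 nM, within 3000 nM to 30000 nM. The expected step is a number no higher from compound 2 to compound 3 (the limit leaves the size open).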

Compound 3, half-maximal inhibitory concentration: 8700 nM
For compound 3 the middle estimate is 1.1-fold (0.06 log units) above the measured one; low and high end bracket the measured number.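

Within the data shown here, with cyano on this aromatic carbon, compound 3 gives 8700 nM in this assay, the first value at this position on the shared core that is a number and not a limit. This gives an at least 1.1-fold lower number from compound 2 to compound 3 (0.06 log units; that floor lies within the scatter) and an at least 1.1-fold lower number from compound 1 to compound 3 (0.06 log units; that floor lies within the scatter). The true size of each step stays open because compound 1 and compound 2 stand only at a limit of the assay: the limit of > 10000 nM in this assay, at which 2 of the 3 values shown sit.

Going by these compounds, whether the cyano compound truly lies beyond the scatter of the other two remains open. So does what an amine or a carboxylic acid on this aromatic carbon would give.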